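Replacing Methoxy with Fluoro in Compound 3

This account rests on a few compounds, and the source may have more. Where it says the series, first, only, none or still open, it means among the compounds named here.

In a functional assay on A549 cells (Homo sapiens) for inhibition, read by MTT assay, with a stated time of 72 h (on this read-out lower numbers stand for stronger inhibition and higher numbers for weaker inhibition), compound 1 `Clc1ccc(-c2nnc(SCCCN3CCN(c4nc5ccccc5o4)CC3)o2)cc1` gives 127000 nM, compound 2 `O=C(NCc1nnc(SCCCN2CCN(c3nc4ccccc4o3)CC2)o1)c1ccccc1` gives 102000 nM and compound 3 `COc1ccc(-c2nnc(SCCCN3CCN(c4nc5ccccc5s4)CC3)o2)cc1` gives 90300 nM, so compound 3 stands within the scatter of both. Compound 4 `Fc1ccc(-c2nnc(SCCCN3CCN(c4nc5ccccc5s4)CC3)o2)cc1` differs from compound 3 in one place: fluoro in place of methoxy on an aromatic carbon. Among the compounds with values here, no measured step makes this exact swap. Within the data shown here, the only step available, a 1.2-fold lower number from compound 1 to compound 2 (0.10 log units; within the scatter), exchanges 4-chlorophenyl for the larger benzamidomethyl, yet stays within the scatter. A swap this small is therefore expected to cause no step beyond the scatter in this assay. The estimated step is a 1.1-fold higher number from compound 3 to compound 4 (0.02 log units; within the scatter). Compound 4 is expected at 95000 nM, with an estimated range from 50000 nM to 180000 nM.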

Compound 4, half-maximal inhibitory concentration: 71700 nM
Compound 4: the middle estimate sits 1.3-fold (0.12 log units) above what was measured, and the stated range covers the measured number.
By their numbers in this assay, from the lowest: compounds 4, 3, 2 and 1 (each within the scatter of the next).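

Within the data shown here, this is the first direct reading at this position. Going from 4-methoxyphenyl to 4-fluorophenyl takes away one heavy atom and the group's hydrogen-bond acceptor, yet in this assay the result is a 1.3-fold lower number from compound 3 to compound 4 (0.10 log units; within the scatter), so this swap leaves the two compounds indistinguishable. Nothing available here offers an explanation for this result. Going by these compounds, whether a group of another kind at this place, such as an amine or a carboxylic acid, would produce a step beyond the scatter remains open. So does the effect of a longer chain there.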